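Amide side-chain amines: compound 3 to compound 4

The source may report more compounds than this note shows. Statements on the series, on what has been measured and on what is new or still open speak of the compounds shown alone.

compound 1 `CC(C)CNCC(=O)N1N=C(c2cc3ccccc3oc2=O)CC1c1ccccc1` — 1920 nM
compound 2 `CC1CCCCN1CC(=O)N1N=C(c2cc3ccccc3oc2=O)CC1c1ccccc1` — 36300 nM
compound 3 `CC1CC(C)CN(CC(=O)N2N=C(c3cc4ccccc4oc3=O)CC2c2ccccc2)C1` — "not active" (no number reported)

All three were run in a functional assay on PC-3 cells (Homo sapiens) for cytotoxicity, read by MTT assay, with a stated time of 48 h; a higher number here means a weaker inhibitor, a lower number a stronger inhibitor. Compound 3 stands without a number: in this assay compound 3 is reported as "not active" (no number reported), whereas compound 1 gives 1920 nM and compound 2 gives 36300 nM. Compound 4 `CCN(CC)C1CCN(CC(=O)N2N=C(c3cc4ccccc4oc3=O)CC2c2ccccc2)CC1` differs from compound 3 by 4-(diethylamino)piperidin-1-yl in place of 3,5-dimethylpiperidin-1-yl on a saturated chain carbon bound to a carbonyl carbon. Going by the values given here, the only measured step, a 19-fold higher number from compound 1 to compound 2 (1.28 log units; beyond the scatter), bears on it indirectly: it shows a large weakening when isobutylamino becomes 2-methylpiperidin-1-yl, and compound 3 with 3,5-dimethylpiperidin-1-yl gives no number at all. Compound 4 keeps a six-membered non-aromatic ring with 1 hetero atom at the same place, so a weak result is expected, with a real chance of no number. Compound 4 is estimated at 40000 nM in this assay, range 8000 nM to 200000 nM.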

Compound 4, half-maximal inhibitory concentration: 26100 nM
The estimate for compound 4 lay 1.5-fold (0.19 log units) above the measured number, within the range that was stated.
By their numbers in this assay, from the lowest: compound 1; then compounds 4 and 2 (each within the scatter of the next).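

In this assay, going by these compounds alone, the place on a saturated chain carbon bound to a carbonyl carbon can carry 4-(diethylamino)piperidin-1-yl and still give a number, whereas compound 3 gives none, so no step to compound 3 can be read. Replacing 2-methylpiperidin-1-yl gives a 1.4-fold lower number from compound 2 to compound 4 (0.14 log units; within the scatter), while replacing isobutylamino gives a 14-fold higher number from compound 1 to compound 4 (1.13 log units; beyond the scatter), so the added diethylamino group does not bring back the number of compound 1. Nothing available accounts for these differences.

Open, as far as these compounds go, is whether morpholin-4-yl or a longer open chain such as n-hexylamino would match or pass compound 1.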